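This account rests on a few compounds, and the source may have more. Where it says the series, first, only, none or still open, it means among the compounds named here.

Compound 1 `CCCCCOCNc1n[n+]([O-])c2ccccc2[n+]1[O-]` gives 17000 nM in a functional assay on SMMC-7721 cells (Homo sapiens) for cytotoxicity, read by MTT assay, with a stated time of 72 h (on this read-out higher numbers stand for weaker inhibition and lower numbers for stronger inhibition), the highest of the three numbers shown, although neither gap to the other two goes beyond the scatter. Compound 2 `CCCCCOCNc1n[n+]([O-])c2cc(OC)ccc2[n+]1[O-]` gives 12900 nM in this assay, and compound 3 `CC(OCNc1n[n+]([O-])c2ccccc2[n+]1[O-])c1ccccc1` gives 12900 nM. Among the compounds with values here, the only single-point step on record, a 1.3-fold lower number from compound 1 to compound 2 (0.12 log units; within the scatter), sits inside the scatter. Compound 4 `CC(C)CCOCNc1n[n+]([O-])c2ccccc2[n+]1[O-]` differs from compound 1 by isopropyl in place of propyl on a saturated chain carbon, two bonds along the chain from an oxygen on a saturated carbon. Within the data shown here, no measured step touches this part of the chain, so branching here has no direct precedent; the values of compound 1 and compound 3 lie close together, which hints that changes along the chain leave the number much where it is. The step expected from compound 1 to compound 4 is therefore a 1.1-fold lower number from compound 1 to compound 4 (0.05 log units; within the scatter). Compound 4 is estimated at 15000 nM, with a range from 7500 nM to 30000 nM.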

Compound 4, half-maximal inhibitory concentration: 15900 nM
Estimate against measurement, compound 4: 1.1-fold (0.03 log units) below; the measured number falls inside the stated range.
By their numbers in this assay, from the lowest: compounds 2, 3, 4 and 1 (each within the scatter of the next).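

Isopropyl in place of propyl, on a saturated chain carbon two bonds along the chain from an oxygen on a saturated carbon, gives a 1.1-fold lower number from compound 1 to compound 4 (0.03 log units; within the scatter) in this assay and provides the first direct reading at this place. Rearranging the same atoms into this branch therefore leaves the number within the scatter. No measurement shown explains this result.

As far as these compounds go, whether a longer chain or an amine in place of the isopropyl would move the number beyond the scatter remains open. Also open, from the compounds shown here alone, is whether this branching gives the same result alongside the methoxy of compound 2.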